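Swapping the hydroxyphenyl of compound 3 for a methylphenyl

The compounds below may be only part of what the source reports. "The series", "measured", "known", "first", "only" and "open" are said of these compounds alone.

Measured so far:
Compound 1, `O=S(=O)(Nc1ccccc1)c1ccc(Br)cc1`: 30000 nM
Compound 2, `CN(c1ccccc1)S(=O)(=O)c1ccc(C(C)(C)C)cc1`: 30000 nM
Compound 3, `CC(C)(C)c1ccc(S(=O)(=O)Nc2cccc(O)c2)cc1`: 12000 nM

Three sulfonamides have been tested in a functional assay on A549 cells (Homo sapiens) for inhibition; on this read-out higher numbers stand for weaker inhibition of growth and lower numbers for stronger inhibition of growth. Among them compound 3 has the lowest number, so it is the strongest inhibitor of growth of the three; compound 1 and compound 2 both stand above it, and each gap is beyond the usual scatter of repeated measurements.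

The next compound, compound 4 with the structure `Cc1ccccc1NS(=O)(=O)c1ccc(C(C)(C)C)cc1`, is not yet measured. It keeps the tert-butyl-bearing part of compound 3 and changes only the group on the other side: 2-methylphenyl in place of 3-hydroxyphenyl on a sulfonamide nitrogen.

Among the measured compounds shown here, no pair of measured compounds differs in just one place, so no measured step tells how such a change behaves here. Compound 1, which also lacks a hydroxyl-bearing ring, gives 30000 nM, but it differs from compound 3 in two places at once, so it is only a loose hint. Compound 4 is expected to come out somewhat weaker than compound 3, with an estimated step of a 1.7-fold higher number from compound 3 to compound 4 (0.22 log units; within the scatter), possibly within the scatter. The estimate for compound 4 is 20000 nM, with a range from 8000 nM to 50000 nM.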

Compound 4, concentration for 50% growth inhibition: > 80000 nM
Compound 4 gave a limit, no number; the forecaster's own chance of this, stated with the estimate: 25%; middle value at least 4.0-fold (0.60 log units) away from the limit.
By their numbers in this assay, from the lowest: compound 3; then compounds 1 and 2 (each within the scatter of the next). At a limit, above all of these: compound 4.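

In this assay compound 4 gives only a limit (> 80000 nM) and no number. This is the first change in a single place among these compounds, and it shows that the group on the sulfonamide nitrogen matters: 2-methylphenyl in place of 3-hydroxyphenyl weakens growth inhibition (an at least 6.6-fold higher number from compound 3 to compound 4 (0.82 log units; beyond the scatter)). The full size of this loss cannot be read, since compound 4 stands at the end of the measured range: (the limit of > 80000 nM in this assay, at which 1 of the 4 values shown sits).

The swap removes the hydroxyl and adds the methyl at once, so the step cannot say which of the two accounts for the loss. Going by these compounds, whether another group on this ring, such as a methoxy group, an amine or a carboxylic acid, would keep or improve on the growth inhibition of compound 3 remains open.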